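The source may report more compounds than this note shows. Statements on the series, on what has been measured and on what is new or still open speak of the compounds shown alone.

In a functional assay on MDA-MB-231 cells (Homo sapiens) for cytotoxicity, read by MTT assay, with a stated time of 72 h (on this read-out higher numbers stand for weaker inhibition and lower numbers for stronger inhibition), compound 1 `COc1ccc(-c2cc(/N=C3/NC(=O)CS3)cs2)cc1` gives > 50000 nM. That value is a limit and not a number. Going by the values given here, compound 2 `O=C1N/C(=N/c2csc(-c3ccc(Cl)cc3)c2)S/C1=C\c1ccccc1` gives 18000 nM, the only true number so far, so it is the single fixed point from which to look ahead. Compound 3 `CN(C)c1ccc(/C=C2\S/C(=N\c3csc(-c4ccc(Cl)cc4)c3)NC2=O)cc1` has not yet been measured. It differs from compound 2 in one place, where phenyl becomes 4-(dimethylamino)phenyl: dimethylamino in place of hydrogen on an aromatic carbon, para to a large group (dimethylamino in place of hydrogen on an aromatic carbon). Among the compounds with values here, no measured pair shows what such a change does, so any forecast here is cautious. In this assay, the expected step of a 1.5-fold lower number from compound 2 to compound 3 (0.18 log units; within the scatter) is small, leaning toward stronger inhibition and possibly no larger than the usual scatter. Compound 3 is estimated at 12000 nM, with an expected range from 3500 nM to 40000 nM.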

Compound 3, half-maximal inhibitory concentration: 800 nM
Compound 3: the middle estimate sits 15-fold (1.18 log units) above what was measured; the measured number lies below the stated range.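

Going by these compounds alone, until now no measured pair showed whether this position on the phenyl ring could affect the read-out at all. In this assay the change from phenyl to 4-(dimethylamino)phenyl, which adds only 3 heavy atoms on an aromatic carbon, gives a 23-fold lower number from compound 2 to compound 3 (1.35 log units; beyond the scatter) and so marks this position as highly sensitive to what is placed there. Nothing in the data explains why a single group has so large an effect.

This one pair leaves open whether the gain is specific to dimethylamino or would also appear with another group in the same place, such as a primary amine, a carboxylic acid or a longer chain. It also leaves open whether dimethylamino would give a similar step on a different core.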